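This account rests on a few compounds, and the source may have more. Where it says the series, first, only, none or still open, it means among the compounds named here.

Working notes on the diaryl ether urea series

Compound 1 `O=C(Nc1ccc(Cl)cc1)Nc1ccc(Oc2ccc(-c3nccs3)cc2)cc1` carries a 4-chlorophenyl on one urea nitrogen. In a functional assay on MDA-MB-231 cells (Homo sapiens) for inhibition, read by MTT assay and WST assay, with a stated time of 72 h, tested at 10 uM (on this read-out lower numbers stand for less inhibition of growth and higher numbers for more inhibition of growth at the one concentration tested), compound 1 gives 32.5%. Compound 2 `O=C(Nc1ccccc1)Nc1ccc(Oc2ccc(-c3nccs3)cc2)cc1`, the unsubstituted phenyl analogue, has no result in this assay: compound 2 is recorded as "not determined" (no result reported). Compound 3 `O=C(Nc1ccc(Oc2ccc(-c3nccs3)cc2)cc1)Nc1ccc(F)c(Cl)c1` differs from compound 1 only in the aryl on the urea nitrogen; in this assay compound 3 gives 43.9%. Going by the values given here, the single measured step, a number 11.4 percentage points higher from compound 1 to compound 3 (beyond the scatter), places compound 1 as the lower of the two numbers available, with compound 3 beyond the scatter above it.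

Compound 4 `O=C(Nc1ccc(Cl)cc1)Nc1ccc(Oc2ccc(-c3ncc[nH]3)cc2)cc1` keeps the 4-chlorophenyl urea of compound 1 and changes the far end of the shared core: 1H-imidazol-2-yl in place of 1,3-thiazol-2-yl on an aromatic carbon. Among the compounds with values here, no measured step in this assay touches that end of the molecule; the one step on record, from compound 1 to compound 3, concerns the urea aryl only and is modest in size. No information therefore speaks for a directional change at the five-membered ring, and the expectation is that compound 4 stays near compound 1, with any step within the scatter.

The estimated step, a number 0.5 percentage points lower from compound 1 to compound 4 (within the scatter), is expected to be small. For compound 4 the expected value in this assay is 32%, in the range 15% to 50%.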

Compound 4, percent growth inhibition at one concentration: 47.6%
Compound 4: the middle estimate sits 15.6 percentage points below what was measured; measured number inside the range.
By their numbers in this assay, from the lowest: compound 1; then compounds 3 and 4 (each within the scatter of the next).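

The five-membered ring at the far end of the shared core is not a silent position in this assay: 1H-imidazol-2-yl in place of 1,3-thiazol-2-yl gives a number 15.1 percentage points higher from compound 1 to compound 4 (beyond the scatter). Going by these compounds alone, until now the only reading came from the urea aryl, with a number 11.4 percentage points higher from compound 1 to compound 3 (beyond the scatter), so the growth inhibition of this series now responds to a change at either end of the molecule, each step modest in size. The exchange keeps a five-membered aromatic ring with 2 hetero atoms and replaces sulfur with a nitrogen, adding 1 hydrogen-bond donor, but no supporting data link the step to this or any other difference between the two groups.

Whether the step at the five-membered ring carries over to the 3-chloro-4-fluorophenyl urea of compound 3 remains open, since that aryl and 1H-imidazol-2-yl do not occur together in the compounds shown. Also open, as far as these compounds go, is how a 1-methyl-1H-imidazol-2-yl or a 1,3-oxazol-2-yl at the same place would read, which would test whether the hydrogen on the ring nitrogen or the loss of sulfur goes with the step.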